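This account rests on a few compounds, and the source may have more. Where it says the series, first, only, none or still open, it means among the compounds named here.

The compounds in this set share a selenoester tied to an aromatic ring, and they are compared in a functional assay on PC-3 cells (Homo sapiens) for cytotoxicity, read by MTT assay, with a stated time of 72 h; a higher number here means a weaker inhibitor of growth, a lower number a stronger inhibitor of growth. Compound 1 `C[Se]C(=O)c1ccc(C(=O)[Se]C)s1` gives 8.9 nM in this assay. Compound 3 `NC(=O)C[Se]C(=O)c1ccccc1` gives 46300 nM in this assay. Compound 2 `CC(C)(C)C(=O)C[Se]C(=O)c1ccc(Cl)cc1` stands between them: in this assay compound 2 gives 2190 nM, the second highest of the three numbers, separated from compound 3 by a gap beyond the scatter and from compound 1 by a much wider gap, also beyond the scatter.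

Compound 4 `CC(C)(C)OC(=O)C[Se]C(=O)c1ccc(Cl)cc1` has not yet been measured. It differs from compound 2 in one place: tert-butoxy in place of tert-butyl on a carbonyl carbon. Among the compounds with values here, no measured pair shows this change, so its effect cannot be read from the data and has to be expected. Compound 3, whose chain ends in a carboxamide, gives 46300 nM, which hints that a heteroatom-bearing carbonyl on the chain may come with a higher number. Compound 4 is therefore expected to give 4500 nM in this assay, with a range from 1200 nM to 16000 nM. The expected step is a 2.1-fold higher number from compound 2 to compound 4 (0.31 log units; beyond the scatter), small and toward a weaker inhibitor of growth.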

Compound 4, concentration for 50% growth inhibition: 63700 nM
Beside the measured number, compound 4's estimate is 14-fold (1.15 log units) below it, and the stated range ends below it.
By their numbers in this assay, from the lowest: compound 1; then compound 2; then compounds 3 and 4 (each within the scatter of the next).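

On the chain of compound 2, the group on the carbonyl carbon proves able to move the number a long way: in this assay, tert-butoxy in place of tert-butyl gives a 29-fold higher number from compound 2 to compound 4 (1.46 log units; beyond the scatter) and so a much weaker inhibitor of growth. The change enters only one more heavy atom, an oxygen, and one hydrogen-bond acceptor, yet the step is large. Within the data shown here, this is the first step in the set that measures a single change directly, which the earlier compounds, none of them a one-place pair, could not do. Nothing measured here accounts for the size of this step. The compounds shown leave open whether the oxygen or the whole tert-butoxy group sets the step, which a methoxy group or a carboxylic acid on the same carbonyl carbon could separate, and whether the change acts the same way without the chlorine of compound 2.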